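The compounds below may be only part of what the source reports. "The series", "measured", "known", "first", "only" and "open" are said of these compounds alone.

Working notes on the series. Compound 1 `C(=N/Nc1nc(-c2ccccc2)cs1)\c1ccc(N2CCCC2)cc1` and compound 2 `Fc1ccc(-c2csc(N/N=C/c3ccc(N4CCCC4)cc3)n2)cc1` share a core and differ only by a fluoro in place of hydrogen on an aromatic carbon. In an assay on isolated protein for inhibition of Amine oxidase [flavin-containing] A (Homo sapiens), read by fluorescence and Amplex Red, with a stated time of 30 min (a lower number here means a stronger inhibitor, a higher number a weaker inhibitor), compound 1 gives 25600 nM, and compound 2 gives 13100 nM; the step of a 2.0-fold lower number from compound 1 to compound 2 (0.29 log units; within the scatter) lies within the scatter, so compound 2 sits alongside compound 1 rather than apart from it. Compound 3 `Clc1ccc(-c2csc(N/N=C/c3ccc(N4CCCC4)cc3)n2)c(Cl)c1` carries the change (2,4-dichlorophenyl in place of 4-fluorophenyl on an aromatic carbon). Within the data shown here, the only measured step that bears on halogen substitution on that phenyl, a 2.0-fold lower number from compound 1 to compound 2 (0.29 log units; within the scatter), was small; a step of similar size is therefore expected, at most a modest lowering. Compound 3 is estimated at 9000 nM in this assay, range 3000 nM to 30000 nM, meaning an expected step of a 1.5-fold lower number from compound 2 to compound 3 (0.16 log units; within the scatter).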

Compound 3, half-maximal inhibitory concentration: 103000 nM
For compound 3 the middle estimate is 11-fold (1.06 log units) below the measured one, and the stated range ends below it.
By their numbers in this assay, from the lowest: compounds 2 and 1 (each within the scatter of the next); then compound 3.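

Among these compounds, at this aromatic carbon of the five-membered ring, 2,4-dichlorophenyl gives the first change beyond the scatter in this assay, upward against both neighbours (a 7.9-fold higher number from compound 2 to compound 3 (0.90 log units; beyond the scatter)) and (a 4.0-fold higher number from compound 1 to compound 3 (0.60 log units; beyond the scatter)). The phenyl substituent here is therefore not indifferent, and compound 3 stands as the weakest of the three. Nothing available explains this rise. Going by these compounds, whether one chlorine is enough remains open, and 4-chlorophenyl would separate the two chlorines. On these data alone, how a methoxy group or an amine on that phenyl would read also remains open.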